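This account rests on a few compounds, and the source may have more. Where it says the series, first, only, none or still open, it means among the compounds named here.

Working notes on the series built on the shared core.

Compound 1 `O=C1NCCN(c2cccc(Cl)c2)N1` gives 2100 nM in a functional assay on cells for inhibition of Polyunsaturated fatty acid 5-lipoxygenase (Homo sapiens); on this read-out lower numbers stand for stronger inhibition and higher numbers for weaker inhibition. Compound 2 `O=C1NCCN(c2cccc(OCc3ccccc3)c2)N1` gives 200 nM in this assay. Compound 3 `O=C1NC(Oc2ccccc2)CN(c2ccccc2)N1` gives 2600 nM in this assay. Compound 3 carries the highest of the three numbers; the number of compound 1 sits within the scatter of it, so those two read alike, while the number of compound 2 lies beyond the scatter below it, so compound 2 is the more potent of that pair. Among the measured compounds shown here, no two of these three compounds differ in one place only, so no measured step is available to lean on.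

Compound 4 `O=C1NC(Oc2ccc(F)cc2)CN(c2ccccc2)N1` differs from compound 3 in one place: fluoro in place of hydrogen on an aromatic carbon, para to a large group, which one bond further out reads as phenyl to 4-fluorophenyl. For the measured compounds named here, nothing among the measured compounds tests a change of this kind, so the step expected here, a 1.1-fold lower number from compound 3 to compound 4 (0.05 log units; within the scatter), is none beyond the scatter. The estimate for compound 4 in this assay is 2300 nM, with a range from 900 nM to 6000 nM.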

Compound 4, half-maximal inhibitory concentration: 2600 nM
For compound 4 the middle estimate is 1.1-fold (0.05 log units) below the measured one, and the stated range covers the measured number.
By their numbers in this assay, from the lowest: compound 2; then compounds 1, 3 and 4 (each within the scatter of the next).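

Among the compounds shown here, the phenyl to 4-fluorophenyl change gives the first measured step: in this assay the step reads no change at the digits printed from compound 3 to compound 4 (within the scatter) and so puts fluoro on this aromatic carbon, para to a large group, level with hydrogen. This position therefore accepts a single fluoro with no visible shift in the read-out, which compounds 1, 2 and 3 could not show, as none of them differ in one place only. Nothing at hand offers an explanation for this flat step.

Going by these compounds, whether the position stays as indifferent to a larger or charged group, such as methoxy, an amine or a carboxylic acid, remains open. Also open, on these data alone, is whether fluoro would behave the same way on the other aromatic ring of compound 3.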